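The compounds below may be only part of what the source reports. "The series", "measured", "known", "first", "only" and "open" are said of these compounds alone.

Compound 1 `Cc1ccccc1-c1cc(C(C)(C)C)cc(C(C)C)c1CO`: > 50000 nM
Compound 2 `CC(C)c1cc(C(C)(C)C)cc(-c2cccc(C(F)(F)F)c2)c1CO`: > 50000 nM

In a functional assay on RKE cells for antagonist activity at Vasoactive intestinal polypeptide receptor 1 (Rattus norvegicus), read by HTRF and cAMP accumulation, with stated times of 10 min and 30 min (on this read-out higher numbers stand for weaker inhibition and lower numbers for stronger inhibition), compound 1 gives only a limit, > 50000 nM. Compound 2 likewise gives only a limit, > 50000 nM. Compound 2 therefore stands at the limit of > 50000 nM in this assay, at which 2 of the 2 values shown sit, with no number of its own. Compound 3 `CC(C)c1cc(C(C)(C)C)cc(-c2cccc(C#N)c2)c1CO` differs from compound 2 by cyano in place of trifluoromethyl on an aromatic carbon. Among the compounds with values here, no step between measured compounds is known, so in this assay no change beyond the scatter is expected, and a limit is likely again. For compound 3 the estimate is 50000 nM, between 15000 nM and 200000 nM, an expected step of a number no higher from compound 2 to compound 3 (the limit leaves the size open).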

Compound 3, half-maximal inhibitory concentration: > 50000 nM
Compound 3: only a limit was reported; the forecaster's own chance of this, stated with the estimate: 75%; the middle value lies on the limit itself.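

Within the data shown here, compound 2 and compound 3 each give only a limit in this assay, so no step between them can be read. The compounds shown leave open how strongly any of them inhibits, and whether cyano and trifluoromethyl differ at all here.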